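A methyl for a difluoromethyl: the free fraction in question

The source may report more compounds than this note shows. Statements on the series, on what has been measured and on what is new or still open speak of the compounds shown alone.

Measured in an ADME assay on the whole organism (plasma, Mus musculus, strain CD-1) for protein binding, read by LC-MS, with a stated time of 24 h; on this read-out higher numbers stand for a larger free fraction and lower numbers for a smaller free fraction:
Compound 1 (`Cc1noc(-c2ccc(Oc3ccc(C(=O)O)cc3)cc2)c1NC(=O)O[C@H](C)c1ccccc1`) gives 0.005
Compound 2 (`CN(CC1CCC1)C(=O)OCc1c(-c2ccc(O[C@H]3CCC[C@H](C(=O)O)C3)c(C(F)F)n2)nnn1C`) gives 0.035

Compound 2 holds the higher of the two numbers in this assay (0.035), while compound 1 stands lower (0.005), and the gap between them lies beyond the usual scatter of repeated measurements. Compound 3 (`Cc1nc(-c2nnn(C)c2COC(=O)N(C)CC2CCC2)ccc1O[C@H]1CCC[C@H](C(=O)O)C1`) has not yet been measured. It keeps the rest of compound 2 and carries methyl in place of difluoromethyl on an aromatic carbon, next to the ring nitrogen of the six-membered aromatic ring (methyl in place of difluoromethyl on an aromatic carbon). For the measured compounds named here, no pair of measured compounds in this set shows this change, so the data give no direct guide to its size or direction. Going by the values given here, the only anchor is the value of compound 2 (0.035), the closer of the two structures. The estimate is a step of a 1.3-fold higher number from compound 2 to compound 3 (0.11 log units; within the scatter) that stays within the scatter, leaning slightly towards a larger free fraction. Compound 3 is expected at 0.045 in this assay (estimated range 0.02 to 0.09).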

Compound 3, unbound fraction: 0.1
For compound 3 the middle estimate is 2.2-fold (0.35 log units) below the measured one, outside the stated range (above it).
By their numbers in this assay, from the lowest: compound 1; then compound 2; then compound 3.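

In this assay, methyl in place of difluoromethyl on an aromatic carbon, next to the ring nitrogen of the six-membered aromatic ring, gives a 2.9-fold higher number from compound 2 to compound 3 (0.46 log units; beyond the scatter). For the compounds shown here, this is the first change in the set that can be read in one place, and it shows that this position alone can move the free fraction beyond the usual scatter, in the upward direction when methyl, with 1 heavy atom, enters and difluoromethyl, with 3 heavy atoms, leaves. Nothing measured here accounts for the step, so the reason for it stays unknown.

The compounds shown leave open how an ethyl, a methoxy or a trifluoromethyl group at this same place would read in this assay, and so whether the free fraction follows the presence of fluorine, the size of the group, or something else. They also rest on a single pair, which leaves open whether the same exchange would give a step of similar size and direction with a different carbamate or with another group in place of the carboxylic acid.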